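A few compounds are considered here, and "the series" means these few. Any claim that something is new, unique, unknown or untested is made for them only; others in the source may bear on it.

In an assay on isolated protein for inhibition of kynurenine 3-monooxygenase (Rattus norvegicus) (on this read-out higher numbers stand for weaker inhibition and lower numbers for stronger inhibition), compound 3, with the structure `CC(C)c1ccc(S(=O)(=O)Nc2nc(-c3cccc([N+](=O)[O-])c3)cs2)cc1`, gives 990 nM. Among the three compounds measured so far it stands second highest, which on this read-out means the second weakest inhibition. Its nearest neighbour is compound 2, `O=C(O)CCC(=O)c1cccc([N+](=O)[O-])c1`, which in this assay gives 5770 nM, a gap said to lie beyond the scatter. Furthest away is compound 1, `Cc1ccc(S(=O)(=O)Nc2nc(-c3ccc(Cl)c(Cl)c3)cs2)cc1`, which in this assay gives 56 nM; compound 1 differs from compound 3 in more than one place, so its lower number cannot be tied to any single change.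

Compound 4, `O=[N+]([O-])c1cccc(-c2csc(NS(=O)(=O)c3ccc(Cl)cc3)n2)c1`, has not yet been measured in this assay. It differs from compound 3 by one change, (chloro in place of isopropyl on an aromatic carbon), chloro in place of isopropyl on an aromatic carbon, para to a large group; at one bond further out, 4-isopropylphenyl becomes 4-chlorophenyl. Among the measured compounds shown here, no measured pair shows this exact change, so the expectation rests on the values of compounds 1, 2 and 3 alone. A modest step toward a lower number, possibly within the scatter, is expected from compound 3 to compound 4, a 2.0-fold lower number from compound 3 to compound 4 (0.30 log units; within the scatter). Compound 4 is therefore estimated at 500 nM in this assay, with a range from 150 nM to 1700 nM.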

Compound 4, half-maximal inhibitory concentration: 84 nM
Compound 4: middle estimate off by 6.0-fold (0.77 log units), on the high side, outside the stated range (below it).
By their numbers in this assay, from the lowest: compounds 1 and 4 (each within the scatter of the next); then compound 3; then compound 2.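

Among the compounds shown here, this is the first pair of compounds here that differ in one place, so a change in the number can now be tied to a single swap: when 4-isopropylphenyl becomes 4-chlorophenyl, this assay shows a 12-fold lower number from compound 3 to compound 4 (1.07 log units; beyond the scatter). The earlier compounds shown here could not show this, as none of them formed such a pair. The result shows that this position on the six-membered aromatic ring, para to a large group, is not indifferent to what it carries, and that replacing isopropyl with the smaller chloro, one heavy atom in place of three, goes with stronger inhibition, while no measurement at hand says why.

A single pair cannot show whether chloro itself matters or whether other groups at this position, such as fluoro, methoxy or an amine, would give a similar number. Going by these compounds, it also remains open whether the same swap would produce a step of similar size in compounds that carry something other than the nitro group on the opposite end of the molecule.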